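Replacing the Fluoro of Compound 3 with a Larger Group

The source may report more compounds than this note shows. Statements on the series, on what has been measured and on what is new or still open speak of the compounds shown alone.

Compound 1 (`O=C(CCSc1ccc2c(/C=C/c3ccccn3)n[nH]c2c1)Nc1cccc(Cl)c1`), compound 2 (`COc1cccc(NC(=O)CCSc2ccc3c(/C=C/c4ccccn4)n[nH]c3c2)c1`) and compound 3 (`O=C(CCSc1ccc2c(/C=C/c3ccccn3)n[nH]c2c1)Nc1ccc(F)c(C(F)(F)F)c1`) share one core and differ in the group on the amide nitrogen. In an ADME assay on BaF3 cells (Mus musculus) for antiproliferative activity, read by CCK-8 assay, with a stated time of 72 h (on this read-out higher numbers stand for weaker inhibition of growth and lower numbers for stronger inhibition of growth), compound 1 gives 9350 nM and compound 2 gives 3840 nM while compound 3 gives 610 nM as the lowest of the three numbers. Unmeasured compound 4 (`CN1CCN(Cc2ccc(NC(=O)CCSc3ccc4c(/C=C/c5ccccn5)n[nH]c4c3)cc2C(F)(F)F)CC1`) has (4-methylpiperazin-1-yl)methyl in place of fluoro on an aromatic carbon of compound 3 ((4-methylpiperazin-1-yl)methyl in place of fluoro on an aromatic carbon). Changing that amide group gave a 2.4-fold lower number from compound 1 to compound 2 (0.39 log units; beyond the scatter) and a 6.3-fold lower number from compound 2 to compound 3 (0.80 log units; beyond the scatter) and also a 15-fold lower number from compound 1 to compound 3 (1.19 log units; beyond the scatter) so such changes can matter. None of these compounds carries so large a group, so the direction remains uncertain. The expected result is a 2.8-fold lower number from compound 3 to compound 4 (0.44 log units; beyond the scatter) as a modest estimated step. Compound 4 is estimated at 220 nM (likely range 45 nM to 1100 nM).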

Compound 4, concentration for 50% growth inhibition: 2480 nM
Estimate against measurement, compound 4: 11-fold (1.05 log units) below; measured number outside the range, above it.
By their numbers in this assay, from the lowest: compound 3; then compounds 4 and 2 (each within the scatter of the next); then compound 1.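

Swapping the single fluorine of compound 3 for the much larger (4-methylpiperazin-1-yl)methyl gave a 4.1-fold higher number from compound 3 to compound 4 (0.61 log units; beyond the scatter) in this assay, with the trifluoromethyl group and the rest of the molecule unchanged. The earlier compounds shown here differed in the amide group as a whole, whereas this step shows that this one position alone can shift the number, here towards weaker inhibition of growth. No measurement shown gives a reason for this step. Going by these compounds, whether the size of the group or its nitrogen atoms matter more remains open. A small methyl group or a morpholin-4-ylmethyl group at this position would help to separate the two.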